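A 2-cyanophenyl swap on compound 2

The source may report more compounds than this note shows. Statements on the series, on what has been measured and on what is new or still open speak of the compounds shown alone.

Within the data shown here, in a functional assay on Shh Light II cells (Mus musculus) for inhibition, read by a luciferase reporter (on this read-out higher numbers stand for weaker inhibition and lower numbers for stronger inhibition), compound 1 `O=C(NC1CCNCC1)N1CCC(c2nc(-c3ccc4ccccc4n3)no2)CC1` gives 2500 nM, while compound 2 `O=C(NC1CCS(=O)(=O)CC1)N1CCC(c2nc(-c3ccc4ccccc4n3)no2)CC1` gives 360 nM, the lower of the two numbers so far. Compound 3 `N#Cc1ccccc1NC(=O)N1CCC(c2nc(-c3ccc4ccccc4n3)no2)CC1` differs from compound 2 by 2-cyanophenyl in place of 1,1-dioxothian-4-yl on an amide-type nitrogen. Among the measured compounds shown here, the one measured step at this place is a 6.9-fold lower number from compound 1 to compound 2 (0.84 log units; beyond the scatter), which is modest. For the measured compounds named here, no measured compound has an aromatic ring there, so the direction remains uncertain. A smaller step toward a lower number is expected, namely a 2.4-fold lower number from compound 2 to compound 3 (0.38 log units; beyond the scatter). For compound 3 the estimated value is 150 nM, with an expected range of 30 nM to 750 nM.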

Compound 3, half-maximal inhibitory concentration: 190 nM
Compound 3: middle estimate off by 1.3-fold (0.10 log units), on the low side, within the range that was stated.
By their numbers in this assay, from the lowest: compounds 3 and 2 (each within the scatter of the next); then compound 1.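

In this assay, an aromatic ring can sit on the amide-type nitrogen without loss: 2-cyanophenyl in place of 1,1-dioxothian-4-yl gives a 1.9-fold lower number from compound 2 to compound 3 (0.28 log units; within the scatter), so these two different rings cannot be told apart here. Measured against piperidin-4-yl, the same group gives a 13-fold lower number from compound 1 to compound 3 (1.12 log units; beyond the scatter), which leaves compound 1 alone apart from the other two. Nothing available explains these results.

Going by these compounds, the role of the nitrile remains open, since a plain phenyl ring offers the direct comparison. A carboxylic acid on that ring is also an open case.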